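Changing the Aryl Group on Compound 2

The source may hold more compounds than are shown below. What is called first, only, known or untested is meant among the compounds shown, and "the series" means these compounds.

For the measured compounds named here, in a functional assay on HepG2 cells (Homo sapiens) for inhibition, read by MTT assay, with a stated time of 72 h (a higher number here means a weaker inhibitor, a lower number a stronger inhibitor), compound 2 (`COc1ccc(-c2cc(C(=O)N3CCC4(CC3)CC(=O)c3nn(C(C)(C)C)cc3O4)c3ccccc3n2)cc1OC`) gives 1560 nM, the only actual number so far. Compound 1 (`Cc1ccccc1-c1cc(C(=O)N2CCC3(CC2)CC(=O)c2nn(C(C)(C)C)cc2O3)c2ccccc2n1`) reads > 10000 nM in this assay, and that is a limit, not a number.

Compound 3 (`CC(C)(C)n1cc2c(n1)C(=O)CC1(CCN(C(=O)c3cc(-c4ccc(N)cc4)nc4ccccc34)CC1)O2`) keeps the shared core but carries 4-aminophenyl in place of 3,4-dimethoxyphenyl on an aromatic carbon, next to the ring nitrogen: 4-aminophenyl in place of 3,4-dimethoxyphenyl on an aromatic carbon.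

Going by the values given here, only one measured step involves this same carbon. It is an at least 6.4-fold lower number from compound 1 to compound 2 (0.80 log units; beyond the scatter), made by putting 3,4-dimethoxyphenyl in place of 2-methylphenyl. That step shows that the group here can matter, but a single step offers no rule for 4-aminophenyl, so any forecast stays loose.

Starting from compound 2 at 1560 nM, a slight loss of inhibition is expected, and it may not clear the usual scatter. The estimated change is a 1.6-fold higher number from compound 2 to compound 3 (0.20 log units; within the scatter), with weaker inhibition as the expected direction. For compound 3 the expected value in this assay is 2500 nM, with an estimated range of 600 nM to 9000 nM.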

Compound 3, half-maximal inhibitory concentration: 630 nM
Compound 3: middle estimate off by 4.0-fold (0.60 log units), on the high side; measured number inside the range.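

For the compounds shown here, the earlier step showed only that the group on this aromatic carbon can matter, and 3,4-dimethoxyphenyl might have seemed the better kind of group to keep. Compound 3 shows that this group can be replaced with a further gain in this assay: the change to 4-aminophenyl gives a 2.5-fold lower number from compound 2 to compound 3 (0.39 log units; beyond the scatter). Measured against the weakest-reading group, 2-methylphenyl, the same 4-aminophenyl gives an at least 15-fold lower number from compound 1 to compound 3 (1.20 log units; beyond the scatter), although compound 1 stands at a limit and not at a number, so the true size of this step remains unknown: the limit of > 10000 nM in this assay, at which 1 of the 3 values shown sits.

The change from compound 2 to compound 3 removes the methoxy groups and adds an amine in one move, so these compounds cannot show which of the two accounts for the lower number. A plain phenyl ring, a single methoxy group on the phenyl ring, or a dimethylamino group in place of the amine would help to separate those two parts of the change, and each would test whether the amine hydrogens matter at this position.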